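This account rests on a few compounds, and the source may have more. Where it says the series, first, only, none or still open, it means among the compounds named here.

Measured so far:
- compound 1 `CCOc1ccc(NC(=O)c2cccc(/C=C3\CC(=O)N(c4ccccc4)C3=O)c2)cc1` — 91500 nM
- compound 2 `CCCCCN1C(=O)C/C(=C\c2cccc(C(=O)Nc3cccc(F)c3)c2)C1=O` — > 100000 nM

Going by the values given here, in an ADME assay on SW480 cells (Homo sapiens) for cytotoxicity, read by MTT assay, with a stated time of 72 h (a lower number here means a stronger inhibitor, a higher number a weaker inhibitor), compound 1 gives 91500 nM, and this is the only plain number among the values shown for the series. Compound 2 gives only the limit of > 100000 nM in this assay. One of the two values shown sits at the limit of > 100000 nM in this assay, at which 1 of the 2 values shown sits, so compound 1 cannot be placed as stronger or weaker against compound 2 beyond saying it produced a number where compound 2 did not.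

Compound 3 `Cc1cccc(NC(=O)c2cccc(/C=C3\CC(=O)N(c4ccccc4)C3=O)c2)c1` has not yet been measured in this assay. It differs from compound 1 by 3-methylphenyl in place of 4-ethoxyphenyl on an amide-type nitrogen. Among the compounds with values here, no step between measured compounds is available to calibrate the change, so no direction is expected beyond the scatter; a step of a 1.0-fold higher number from compound 1 to compound 3 (0.02 log units; within the scatter) is expected, which is within the scatter. For compound 3 the expected value in this assay is 95000 nM, with a range from 45000 nM to 200000 nM.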

Compound 3, half-maximal inhibitory concentration: > 100000 nM
Compound 3 gave a limit, no number; the forecaster's own chance of this, stated with the estimate: 45%; at least 1.0-fold (0.02 log units) between middle value and limit.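

Going by these compounds alone, this is the first pair that differs in one place: with 3-methylphenyl in place of 4-ethoxyphenyl on the amide-type nitrogen, this assay gives an at least 1.0-fold higher number from compound 1 to compound 3 (0.03 log units; that floor lies within the scatter). Compound 3 gives > 100000 nM, which is a limit and not a number, so the step has only a floor and sets no order between the two compounds. The change also drops the one hydrogen-bond acceptor counted on this group without producing a plain number, and limits now make up most of the series: the limit of > 100000 nM in this assay, at which 2 of the 3 values shown sit.

From the compounds shown here alone, it remains open whether a phenyl group carrying an amine or a carboxylic acid at this place would give a plain number in this assay. Also open, going by these compounds, is whether a longer alkoxy chain than the ethoxy of compound 1 would shift the value beyond the scatter.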